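Triazine series: secondary amine in place of dipropylamino

The source may report more compounds than this note shows. Statements on the series, on what has been measured and on what is new or still open speak of the compounds shown alone.

Measured compounds:
- Compound 1 `CCCN(CC1CC1)c1cc(C)nc(N(CC)c2ccc(C(C)C)cc2Br)n1`: 9 nM
- Compound 2 `CCCN(CCC)c1nc(C)nc(N(CC)c2ccc(C(C)C)cc2Br)n1`: 4 nM
- Compound 3 `CCN(CC)c1cc(C)nc(N(CC)c2c(Br)cc(C(C)=O)cc2OC)n1`: 28 nM

All three values come from an assay on isolated protein for binding affinity to corticotropin-releasing factor receptor 1 (Homo sapiens); on this read-out higher numbers stand for weaker inhibition and lower numbers for stronger inhibition. On this read-out compound 2 gives the lowest number of the three; the nearest is compound 1, which gives 9 nM, a gap beyond the scatter, and the furthest is compound 3, which gives 28 nM, also beyond the scatter. Compound 2 is therefore the most potent of the measured set.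

The next compound, compound 4 `CCC(CC)Nc1nc(C)nc(N(CC)c2ccc(C(C)C)cc2Br)n1`, keeps the core of compound 2 and the same bromo-isopropylphenyl arm, and differs in one place: (pentan-3-yl)amino in place of dipropylamino on an aromatic carbon. The group that enters carries a hydrogen-bond donor where the leaving group has none, and is one heavy atom smaller. No measured pair in the series shows this kind of exchange, so the size of the effect cannot be read from the data shown; the expectation rests only on compound 2 and its value 4 nM.

In this assay compound 4 is expected to stay close to compound 2, with a step of a 1.5-fold higher number from compound 2 to compound 4 (0.18 log units; within the scatter) that may fall within the scatter or be a modest change in either direction. The estimate for compound 4 in this assay is 6 nM, in a range from 2 nM to 20 nM.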

Compound 4, inhibition constant: 41 nM
Compound 4: the middle estimate sits 6.8-fold (0.83 log units) below what was measured; measured number outside the range, above it.
By their numbers in this assay, from the lowest: compound 2; then compound 1; then compounds 3 and 4 (each within the scatter of the next).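

In this assay, putting (pentan-3-yl)amino in place of dipropylamino on this aromatic carbon gives a 10-fold higher number from compound 2 to compound 4 (1.01 log units; beyond the scatter), so this position of the shared core is sensitive to the choice of amine even when the heavy-atom count changes only slightly. Among these compounds, this is the first one-place step, and it shows a large loss of affinity rather than a change within the scatter. The single step joins several differences, since the entering group brings a hydrogen-bond donor that the leaving group lacks, has fewer heavy atoms and is attached through a different chain arrangement, and nothing in the data shown accounts for the loss.

Which of these differences carries the loss stays open; methyl(pentan-3-yl)amino would keep the branched chain without the donor, while propylamino would keep a straight propyl chain with the donor. From the compounds shown here alone, it is also open whether the same exchange would have a comparable effect on the core of compound 1, or with the substituted phenyl arm of compound 3.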